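A few compounds are considered here, and "the series" means these few. Any claim that something is new, unique, unknown or untested is made for them only; others in the source may bear on it.

Measured so far in a functional assay on MCF7 cells (Homo sapiens) for antiproliferative activity, read by MTT assay, with a stated time of 48 h (on this read-out lower numbers stand for stronger inhibition and higher numbers for weaker inhibition), are two compounds:
- compound 1 (`COc1cc(/C=C/C(C)=O)ccc1OCc1cn(-c2ccc(NC(=O)c3ccccc3)cc2)nn1`) gives 86700 nM
- compound 2 (`COc1cc(/C=C/C(C)=O)ccc1OCc1cn(-c2ccc(C(F)(F)F)c(C(F)(F)F)c2)nn1`) gives 87400 nM

These two numbers lie within the scatter of each other, so compound 1 stands level with compound 2 and neither can be placed ahead. Compound 3 (`COc1cc(/C=C/C(C)=O)ccc1OCc1cn(-c2ccccc2)nn1`) has not yet been measured. It keeps the core of compound 1 and differs from it in one place (hydrogen in place of benzamido on an aromatic carbon), with hydrogen in place of benzamido on an aromatic carbon.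

Among the measured compounds shown here, no measured pair differs in a single place, so the data offer no step to serve as a guide, and the only anchor is the level of the series: compound 1 at 86700 nM and compound 2 at 87400 nM in the same range. In this assay no change beyond the scatter is therefore expected, and the estimated move is a 1.1-fold lower number from compound 1 to compound 3 (0.03 log units; within the scatter) with no firm direction. The estimate for compound 3 is 80000 nM as a central value, with the expected range running from 35000 nM to 180000 nM in this estimate.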

Compound 3, half-maximal inhibitory concentration: > 100000 nM
Compound 3: no number, only a limit; the forecaster's own chance of this, stated with the estimate: 25%; middle value at least 1.2-fold (0.09 log units) away from the limit.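

In this assay compound 3 gives > 100000 nM, which is a limit of the assay and not a number. This is the first change in one place that the series offers: hydrogen in place of benzamido on an aromatic carbon, para to a large group, gives an at least 1.1-fold higher number from compound 1 to compound 3 (0.06 log units; that floor lies within the scatter), so the loss of the whole benzamido group is not shown to raise the number beyond the scatter, yet nothing shows that the number stays level either. The step is therefore only a floor, and it rests on a single limit: the limit of > 100000 nM in this assay, at which 1 of the 3 values shown sits.

From the compounds shown here alone, how far the true value of compound 3 lies past its limit stays unknown, so the contribution of the benzamido group at this position remains undecided in either direction. The compounds shown also leave open how a smaller group at the same place, such as an amine or a carboxylic acid, would read, and whether any group there can bring the number clearly below the level of compound 1.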